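A few compounds are considered here, and "the series" means these few. Any claim that something is new, unique, unknown or untested is made for them only; others in the source may bear on it.

Measured compounds and their values in this assay:
compound 1, `Cc1nn(-c2ccccc2)c2nc(-c3ccccc3)c(C#N)c(-c3ccccc3O)c12`: > 23000 nM
compound 2, `CCc1ccc(-c2nc3c(c(C)nn3-c3ccccc3)c(-c3ccccc3[N+](=O)[O-])c2C#N)cc1`: > 20000 nM
compound 3, `CCc1ccc(-c2nc3c(c(C)nn3-c3ccccc3)c(-c3ccccc3C(F)(F)F)c2C#N)cc1`: > 20000 nM

All three were tested in an ADME assay on BJ cells (Homo sapiens) for cytotoxicity, with a stated time of 72 h; a higher number here means that more compound is needed for the effect, a lower number that less compound is needed. For compound 1 the value > 23000 nM is a limit of the assay, not a measured number. The value of compound 2 is likewise a limit. So is the value of compound 3. Compound 1 thus stands at a limit, and the two other values shown are limits as well, as summed up in the limit of > 23000 nM in this assay, at which 1 of the 3 values shown sits, and (the limit of > 20000 nM in this assay, at which 2 of the 3 values shown sit). For the measured compounds named here, the one step between measured compounds, a step that the two limits leave unreadable from compound 2 to compound 3, has no readable size because the limit of > 20000 nM in this assay, at which 2 of the 3 values shown sit, holds both of its ends.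

Compound 4, `Cc1nn(-c2ccccc2)c2nc(-c3ccc4c(c3)CCCC4)c(C#N)c(-c3ccccc3O)c12`, differs from compound 1 in one place: 1,2,3,4-tetrahydronaphthalen-6-yl in place of phenyl on an aromatic carbon. No measured step bears on this change, and the only step shown is unreadable, so nothing points to a shift beyond the scatter in this assay. Compound 4 is therefore expected to sit at the limit as well, with the expected step that the limit leaves unreadable from compound 1 to compound 4. The estimate for compound 4 is 25000 nM, ranging from 10000 nM to 60000 nM.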

Compound 4, half-maximal effective concentration: > 20000 nM
Compound 4: only a limit was reported (the forecaster's own chance of this, stated with the estimate: 80%); the middle value lies beyond the limit too.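

For the compounds shown here, compound 1 and compound 4 both carry only limits of the assay in this assay, and no step between them can be read. The compounds shown leave open what concentration gives the half-maximal effect, and whether 1,2,3,4-tetrahydronaphthalen-6-yl in place of phenyl shifts it at all.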